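The compounds below may be only part of what the source reports. "The series", "measured", "known", "first", "only" and "open" are said of these compounds alone.

Measured in an ADME assay on HCT-116 cells (Homo sapiens) for cytotoxicity, read by CellTiter-Glo, with a stated time of 72 h; on this read-out higher numbers stand for weaker inhibition and lower numbers for stronger inhibition:
Compound 1 `Cc1cc(C)c(S(=O)(=O)N2CCC(N3CCC(O)CC3)CC2)c(C)c1` gives > 5000 nM (a limit).
Compound 2 `Cc1cc(C)c(S(=O)(=O)N2CCC(C(=O)N3CCC(C)CC3)CC2)c(C)c1` gives > 5000 nM (a limit).
Compound 3 `Cc1cc(C)c(S(=O)(=O)N2CCC(N3CCCCC3)CC2)c(C)c1` gives > 5000 nM (a limit).

Compound 3 has only a limit and no number, so it holds no rank in the series (the limit of > 5000 nM in this assay, at which 3 of the 3 values shown sit). Compound 4 `Cc1cc(C)c(S(=O)(=O)N2CCC(N3CCC(C)OC3)CC2)c(C)c1` differs from compound 3 on a saturated ring carbon, three ring bonds from the ring nitrogen (a group of 7 heavy atoms (5 carbon, 1 nitrogen, 1 oxygen; one six-membered non-aromatic ring with 2 hetero atoms) in place of a group of 6 heavy atoms (5 carbon, 1 nitrogen; one six-membered non-aromatic ring with 1 hetero atom), on a saturated ring carbon). Going by the values given here, three measured steps bear on this (a step that the two limits leave unreadable from compound 1 to compound 2) (a step that the two limits leave unreadable from compound 1 to compound 3) (a step that the two limits leave unreadable from compound 2 to compound 3) and none has a readable size. No step beyond the scatter is expected in this assay because the limit of > 5000 nM in this assay, at which 3 of the 3 values shown sit, sets the only reference available, and no direction can be assigned. The expected change is a step that the limit leaves unreadable from compound 3 to compound 4 (an estimate). For compound 4 the estimated value is 7000 nM (expected range 3000 nM to 20000 nM).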

Compound 4, half-maximal inhibitory concentration: > 5000 nM
Compound 4: only a limit was reported; the forecaster's own chance of this, stated with the estimate: 90%; the middle value does not contradict the limit.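

Compound 4 gives > 5000 nM, a limit, so no new step can be read and the steps to it from compound 1, compound 2 and compound 3 stay unreadable: the limit of > 5000 nM in this assay, at which 4 of the 4 values shown sit.

Whether any change on this saturated ring carbon gives a numeric value in this assay remains open with the compounds shown.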